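Replacing 1H-imidazol-1-yl with dimethylamino

The source may hold more compounds than are shown below. What is called first, only, known or untested is meant among the compounds shown, and "the series" means these compounds.

Measured in a functional assay on the whole organism for antagonist activity, with Mus musculus as the target; a lower number here means that less compound is needed, a higher number that more compound is needed for the effect:
compound 1 `CC(=O)N(C)C(C)C#CCn1cncc1C`: 1.1 mg/kg
compound 2 `CC(C#CCn1ccnc1)N1CCCC1=O`: 2 mg/kg
compound 3 `Cc1cncn1CC#CC(C)N1CCCC1=O`: 0.45 mg/kg

Among these three numbers, compound 2 and compound 1 lie within the scatter of each other at the upper end, while compound 3 lies clearly lower. The next compound to be tested in this assay is compound 4 `CC(C#CCN(C)C)N1CCCC1=O`, whose value is not yet known. It differs from compound 2 by dimethylamino in place of 1H-imidazol-1-yl on a saturated chain carbon bound to a triple-bonded carbon.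

For the measured compounds named here, only one measured step bears on this change, and it bears indirectly. That step is a 4.4-fold lower number from compound 2 to compound 3 (0.65 log units; beyond the scatter), and it comes from methyl in place of hydrogen on an aromatic carbon. It shows that a small change on the 1H-imidazol-1-yl group can move the number by a modest amount, but the group itself stays in place. Going by the values given here, no measured pair removes that group, so the data give no direction for the present change. The expected step is therefore small in its middle, a 1.5-fold higher number from compound 2 to compound 4 (0.18 log units; within the scatter), and this estimate carries wide uncertainty on both sides. For compound 4 the estimated value is 3 mg/kg, with an expected range from 0.5 mg/kg to 15 mg/kg.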

Compound 4, dose for half-maximal effect: > 100 mg/kg
Compound 4: a limit, no number; the forecaster's own chance of this, stated with the estimate: 15%; at least 33-fold (1.52 log units) between middle value and limit.
By their numbers in this assay, from the lowest: compound 3; then compounds 1 and 2 (each within the scatter of the next). At a limit, above all of these: compound 4.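

Setting dimethylamino in place of 1H-imidazol-1-yl on a saturated chain carbon bound to a triple-bonded carbon gives an at least 50-fold higher number from compound 2 to compound 4 (1.69 log units; beyond the scatter) in this assay, and this is the only step shown that removes the ring from this position. For the compounds shown here, the earlier step, a 4.4-fold lower number from compound 2 to compound 3 (0.65 log units; beyond the scatter), came from methyl in place of hydrogen on an aromatic carbon and kept 1H-imidazol-1-yl in place, so it showed only that a small change on the group moves the number by a modest amount; the new step shows that the number depends far more strongly on which group sits here. The value of compound 4 is a limit of the assay and not a number, so the step has a lower bound but no measured size: the limit of > 100 mg/kg in this assay, at which 1 of the 4 values shown sits.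

The compounds shown leave open whether the ring itself matters or whether dimethylamino is simply a poor choice at this position, a question that 1H-pyrazol-1-yl or a piperidine on the same chain carbon could address. They also leave open whether methyl on a ring of that kind would lower the number as it does from compound 2 to compound 3.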